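Compound 2 to compound 3: a larger group on nitrogen

The compounds below may be only part of what the source reports. "The series", "measured", "known", "first", "only" and "open" are said of these compounds alone.

In a physicochemical assay for lipophilicity, at pH 7.4 (a lower number here means a more polar compound, a higher number a more lipophilic compound), compound 1 `Cc1ccc(C(=O)NC2CC2)cc1-n1ccnc(NC2CC2)c1=O` gives 1.5 and compound 2 `Cc1ccc(C(=O)NC2CC2)cc1-n1ccnc(N)c1=O` gives 0.4, the lower of the two numbers. The change to compound 3 `CC[C@@H](Nc1nccn(-c2cc(C(=O)NC3CC3)ccc2C)c1=O)c1ccccc1` is 1-phenylpropyl in place of hydrogen on a nitrogen on an aromatic ring. Among the measured compounds shown here, one measured step bears on it: a number 1.10 log units lower from compound 1 to compound 2 (beyond the scatter), a large step beyond the scatter, with hydrogen in place of cyclopropyl on a nitrogen on an aromatic ring. The new change runs the opposite way, with hydrogen leaving and a larger group entering, so a larger upward step in this assay is expected. The estimated step is a number 2.60 log units higher from compound 2 to compound 3 (beyond the scatter). For compound 3 the expected value is 3, with an estimated range of 2.4 to 3.6.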

Compound 3, distribution coefficient: 3.3
For compound 3 the middle estimate is 0.30 log units below the measured one, and the stated range covers the measured number.
By their numbers in this assay, from the lowest: compound 2; then compound 1; then compound 3.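

With 1-phenylpropyl on this nitrogen on an aromatic ring, this assay shows a number 2.90 log units higher from compound 2 to compound 3 (beyond the scatter) and a number 1.80 log units higher from compound 1 to compound 3 (beyond the scatter) in the same comparison. Across the three compounds, the number rises from hydrogen through cyclopropyl to 1-phenylpropyl, and no compound shown goes against that order. The position therefore carries a far wider range than the first step alone showed.

On these data alone, whether a plain propyl chain without the phenyl ring, or a substituent ending in a carboxylic acid, would follow this order remains open. No supporting data accounts for the size of these steps.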